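Two Chlorines in Place of Thiophene on the Amide

The source may hold more compounds than are shown below. What is called first, only, known or untested is meant among the compounds shown, and "the series" means these compounds.

In a functional assay on B16 cells (Mus musculus) for inhibition (a higher number here means a weaker inhibitor, a lower number a stronger inhibitor), the measured compounds give these values
Compound 1 `COc1cc(/C=C/C(=O)c2cccc(NC(=O)c3c(Cl)cccc3Cl)c2)ccc1O` gives 1.58 ug/mL
Compound 2 `COc1cc(/C=C/C(=O)c2cccc(NC(=O)c3cccs3)c2)ccc1O` gives 6.93 ug/mL

Compound 2 stands highest of the two numbers. The move to compound 3 `COc1cc(/C=C/C(=O)c2cccc(NC(=O)c3cc(Cl)cc(Cl)c3)c2)ccc1O` brings 3,5-dichlorophenyl in place of thiophen-2-yl on a carbonyl carbon on the same carbonyl carbon. For the measured compounds named here, the one measured step bearing on it is a 4.4-fold higher number from compound 1 to compound 2 (0.64 log units; beyond the scatter) and it is modest, yet beyond the scatter. Compound 1 carries 2,6-dichlorophenyl and compound 3 carries 3,5-dichlorophenyl, so a somewhat smaller step toward a lower number is expected in this assay here. The expected step is a 2.5-fold lower number from compound 2 to compound 3 (0.39 log units; beyond the scatter) by this estimate. Compound 3 is estimated at 2.8 ug/mL with an expected range from 1.1 ug/mL to 7 ug/mL in this assay.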

Compound 3, half-maximal inhibitory concentration: 4.83 ug/mL
Estimate against measurement, compound 3: 1.7-fold (0.24 log units) below; the range from low to high includes it.
By their numbers in this assay, from the lowest: compound 1; then compounds 3 and 2 (each within the scatter of the next).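

In this assay, 3,5-dichlorophenyl on the carbonyl carbon is not told apart from thiophen-2-yl, with a 1.4-fold lower number from compound 2 to compound 3 (0.16 log units; within the scatter) as the step. Changing 2,6-dichlorophenyl to 3,5-dichlorophenyl does register, with a 3.1-fold higher number from compound 1 to compound 3 (0.49 log units; beyond the scatter) as the step, so among these compounds the number depends on where the chlorines stand and not merely on their presence. No evidence is available to explain this. Still open, going by these compounds, is how a single chlorine on the phenyl ring would read, or a morpholine or a simple alkyl chain on the same carbonyl carbon.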